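The source may hold more compounds than are shown below. What is called first, only, known or untested is meant among the compounds shown, and "the series" means these compounds.

Working notes on the series. In a functional assay on Huh-7 cells (Homo sapiens) for antiproliferative activity, read by sulforhodamine B assay, with a stated time of 72 h (on this read-out lower numbers stand for stronger inhibition and higher numbers for weaker inhibition), compound 1 (`OC[C@H]1O[C@@H](n2cnc3c(N4CCN(c5ncccn5)CC4)ncnc32)[C@H](O)[C@@H]1O`) gives "not active" (no number reported) with no number attached. Among the compounds with values here, compound 2 (`Nc1nc(N2CCN(c3ccccc3)CC2)c2ncn([C@@H]3O[C@H](CO)[C@@H](O)[C@H]3O)c2n1`) gives 50000 nM as the only number so far, so it cannot yet be ranked against a second number. Compound 3 (`Nc1nc(N2CCN(c3ccc(F)cc3)CC2)c2ncn([C@@H]3O[C@H](CO)[C@@H](O)[C@H]3O)c2n1`) keeps the frame of compound 2 and carries a single change (fluoro in place of hydrogen on an aromatic carbon): fluoro in place of hydrogen on an aromatic carbon, para to a large group, which turns phenyl into 4-fluorophenyl. Within the data shown here, no step between measured compounds is available, so this change has no direct precedent. Compound 1 and compound 2 differ in more than one place and offer no guide to it. The expected step in this assay is small, with a slight lean towards stronger inhibition, and it may well stay within the usual scatter. This expectation is written as a 1.4-fold lower number from compound 2 to compound 3 (0.15 log units; within the scatter) in the estimate. With compound 2 at 50000 nM as the sole anchor, a result without a number also remains possible. For compound 3 the estimated value is 35000 nM with an expected range from 12000 nM to 90000 nM on this read-out.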

Compound 3, half-maximal inhibitory concentration: > 100000 nM
Compound 3: no number, only a limit; the forecaster's own chance of this, stated with the estimate: 25%; at least 2.8-fold (0.45 log units) between middle value and limit.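

In this assay compound 3 gives > 100000 nM, which is a limit of the assay and not a number. Within the data shown here, this is the first change that can be read directly, and the step from phenyl to 4-fluorophenyl, para to a large group, reads an at least 2.0-fold higher number from compound 2 to compound 3 (0.30 log units; that floor lies within the scatter), so fluoro in place of hydrogen at this position shows no gain in inhibition in this assay. Only a floor can be given for this step, and its true size stays unknown because the result for compound 3 sits at the top of the measurable range: the limit of > 100000 nM in this assay, at which 1 of the 3 values shown sits.

The compounds shown leave open whether a chloro group, a methoxy group or an amine in that same place would give a measurable number in this assay, or whether any replacement of hydrogen there fails to give one. Compound 1 differs from compound 2 and compound 3 in more than one place, so it cannot show whether the same change would behave alike on another frame.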